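The compounds below may be only part of what the source reports. "The series", "measured", "known", "first", "only" and "open" are said of these compounds alone.

Compound 1 `Clc1ccc2nc(Nc3nnc(-c4ccccc4)o3)sc2c1` and compound 2 `Clc1ccc2nc(Nc3nnc(-c4ccccc4Cl)o3)sc2c1` share a core and differ by one group on the outer phenyl ring. In a functional assay on the whole organism (strain Wistar) for inhibition, with Rattus norvegicus as the target, read by paw edema, with stated times of 1 h and 3 h, at a dose of 70 mg/kg by the oral route (a lower number here means less inhibition, a higher number more inhibition at the dose given (going by the name of the read-out)), compound 1 gives 78.8%, and in this assay compound 2 gives 53%. Among the measured compounds shown here, the one step between them, a number 25.8 percentage points lower from compound 1 to compound 2 (beyond the scatter), came with chloro in place of hydrogen on an aromatic carbon. For the measured compounds named here, on the numbers so far, compound 2 stands lowest of the two, with compound 1 the only neighbour and above it beyond the scatter.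

Compound 3 `Clc1ccc(-c2nnc(Nc3nc4ccc(Cl)cc4s3)o2)c(Cl)c1` is the next compound and has not yet been measured in this assay. Against compound 2 the change is chloro in place of hydrogen on an aromatic carbon, which read one bond further out is 2-chlorophenyl to 2,4-dichlorophenyl. Going by the values given here, only the step from compound 1 to compound 2 bears on it, since it is the one case here of chloro entering that ring, and it pointed downward by a modest amount. A second chloro on the same ring is therefore expected to leave the number roughly where compound 2 sits or a little lower, with the expected step of a number 8 percentage points lower from compound 2 to compound 3 (within the scatter) lying within the scatter. Compound 3 is estimated at 45%, with a range from 25% to 65%.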

Compound 3, a percentage reported as inhibition, in the whole organism at one dose (the size of the read-out at that dose, not a potency): 80%
Compound 3: middle estimate off by 35 percentage points, on the low side; measured number outside the range, above it.
By their numbers in this assay, from the lowest: compound 2; then compounds 1 and 3 (each within the scatter of the next).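

In this assay, chloro in place of hydrogen on the aromatic carbon para to the large group gave a number 27 percentage points higher from compound 2 to compound 3 (beyond the scatter), whereas the same kind of change in going to the 2-chlorophenyl compound gave a number 25.8 percentage points lower from compound 1 to compound 2 (beyond the scatter), so on this ring the direction of the step depends on where the chloro enters or on what the ring already carries. Taken together, 2,4-dichlorophenyl in place of phenyl gave a number 1.2 percentage points higher from compound 1 to compound 3 (within the scatter), which shows that the lower number of compound 2 does not persist once the second chloro is present. No measurement here explains why the two chloro steps point in opposite directions.

The compounds shown leave open whether a single chloro para to the large group, with no second chloro on the ring, would give a similar number, which would separate the effect of this position from that of the pair. They also leave open whether the higher number at this position is particular to chloro, or would also appear with another group there, such as a methoxy group, an amine or a carboxylic acid.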